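The compounds below may be only part of what the source reports. "The series", "measured", "known", "first", "only" and "open" are said of these compounds alone.

Values in a functional assay on the whole organism (trachea) with Rattus norvegicus as the target; a lower number here means a smaller maximal response, a higher number a larger maximal response:
compound 1 `CC1(C)C=C(n2ccccc2=O)c2cc(S(N)(=O)=O)ccc2O1`: 92.1%
compound 2 `CCNS(=O)(=O)c1ccc2c(c1)C(n1ccccc1=O)=CC(C)(C)O2`: 87%
compound 3 `CC1(C)C=C(n2ccccc2=O)c2cc(S(=O)(=O)NCc3ccccc3)ccc2O1`: 77.5%

Compound 3 gives the lowest of the three numbers; its gap to compound 2 is within the scatter, its gap to compound 1 beyond it. Compound 4 `CN(c1ccccc1)S(=O)(=O)c1ccc2c(c1)C(n1ccccc1=O)=CC(C)(C)O2` differs from compound 3 by methyl(phenyl)amino in place of benzylamino on a sulfonyl sulfur. For the measured compounds named here, the steps that bear on this are a number 14.6 percentage points lower from compound 1 to compound 3 (beyond the scatter) and a number 9.5 percentage points lower from compound 2 to compound 3 (within the scatter): growing the group on the sulfonamide nitrogen has lowered the maximal response, but the present change keeps the same atoms and only rearranges them, so no step beyond the scatter is expected in this assay, at most a slight further drop. Compound 4 is therefore expected to give 73%, range 60% to 86%, a step of a number 4.5 percentage points lower from compound 3 to compound 4 (within the scatter).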

Compound 4, largest response reached (Emax), in percent of the reference or control that the assay uses: 86.5%
For compound 4 the middle estimate is 13.5 percentage points below the measured one; measured number outside the range, above it.
By their numbers in this assay, from the lowest: compounds 3, 4, 2 and 1 (each within the scatter of the next, the first and the last beyond it).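

In this assay, methyl(phenyl)amino in place of benzylamino on a sulfonyl sulfur gives a number 9 percentage points higher from compound 3 to compound 4 (within the scatter), so this exchange of same-sized groups, with one hydrogen-bond donor fewer, stays inside the scatter. Compound 4 also shows a number 0.5 percentage points lower from compound 2 to compound 4 (within the scatter) and a number 5.6 percentage points lower from compound 1 to compound 4 (within the scatter), so a group of these 8 heavy atoms does not by itself give a step beyond the scatter from compound 1, whereas benzylamino does in a number 14.6 percentage points lower from compound 1 to compound 3 (beyond the scatter). Nothing available here explains these steps. Open remain morpholine and a longer chain such as phenethylamino on the sulfonyl sulfur.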